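A few compounds are considered here, and "the series" means these few. Any claim that something is new, unique, unknown or untested is made for them only; others in the source may bear on it.

All values below come from a functional assay on MCF7 cells (Homo sapiens) for antiproliferative activity, read by MTT assay, with a stated time of 72 h; a lower number here means a stronger inhibitor, a higher number a weaker inhibitor.

- Compound 1 `O=C(N/N=C/c1ccco1)c1cccc(S(=O)(=O)N2CCOCC2)c1`: > 100000 nM (a limit, not a number)
- Compound 2 `O=C(N/N=C/c1ccccc1O)c1cccc(S(=O)(=O)N2CCOCC2)c1`: 29100 nM
- Compound 3 `O=C(N/N=C/c1cc(Br)ccc1O)c1cccc(S(=O)(=O)N2CCOCC2)c1`: 26600 nM

Compound 3 cannot be told apart from compound 2 on these numbers, and the two stand well clear of the limit of compound 1. Compound 4 `O=C(N/N=C/c1cc(Br)cc(Br)c1O)c1cccc(S(=O)(=O)N2CCOCC2)c1` carries a bromo in place of hydrogen on an aromatic carbon, ortho to a hydroxy group (bromo in place of hydrogen on an aromatic carbon).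

Among the compounds with values here, the closest precedent is the same kind of change, a 1.1-fold lower number from compound 2 to compound 3 (0.04 log units; within the scatter). The steps of an at least 3.4-fold lower number from compound 1 to compound 2 (0.53 log units; beyond the scatter) and an at least 3.7-fold lower number from compound 1 to compound 3 (0.57 log units; beyond the scatter) replace furan-2-yl, a different change, so they bear on this one less. No step beyond the scatter is therefore expected in this assay. The expected step is a 1.2-fold lower number from compound 3 to compound 4 (0.08 log units; within the scatter). For compound 4 the estimated value is 22000 nM, with an expected range from 9000 nM to 55000 nM.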

Compound 4, half-maximal inhibitory concentration: 16000 nM
Beside the measured number, compound 4's estimate is 1.4-fold (0.14 log units) above it; the range from low to high includes it.
By their numbers in this assay, from the lowest: compounds 4, 3 and 2 (each within the scatter of the next). At a limit, above all of these: compound 1.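

On this carbon, ortho to a hydroxy group, a bromo in place of hydrogen gives a 1.7-fold lower number from compound 3 to compound 4 (0.22 log units; within the scatter), so a second bromo on the ring is tolerated in this assay. Having both bromo groups, as 3,5-dibromo-2-hydroxyphenyl in place of 2-hydroxyphenyl, gives a 1.8-fold lower number from compound 2 to compound 4 (0.26 log units; within the scatter), so this pair also stays close. In place of furan-2-yl, the same group gives an at least 6.2-fold lower number from compound 1 to compound 4 (0.79 log units; beyond the scatter), a step read against a limit rather than a number: the limit of > 100000 nM in this assay, at which 1 of the 4 values shown sits.

Going by these compounds, whether an amine or a methoxy group on this carbon would match bromo remains open. So does the result of replacing the hydroxy group with a methoxy group.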